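The source may report more compounds than this note shows. Statements on the series, on what has been measured and on what is new or still open speak of the compounds shown alone.

Three compounds have numbers in an ADME assay on HepG2 2.2.15 cells (Homo sapiens) for cytotoxicity, read by MTT assay, with stated times of 48 h and 9 days; a lower number here means that less compound is tolerated, a higher number that more compound is tolerated. Compound 1 `O=C(/C=C/c1coc2cc(O)ccc2c1=O)NCc1ccccc1` gives 436000 nM, compound 2 `COc1ccc2c(=O)c(/C=C/C(=O)Nc3ccccc3)coc2c1` gives 523000 nM, and compound 3 `COc1ccc2c(=O)c(/C=C/C(=O)Nc3ccccc3Cl)coc2c1` gives 1010000 nM. The number for compound 3 lies beyond the scatter from that of compound 1, but it cannot be separated from that of compound 2, as a 1.9-fold higher number from compound 2 to compound 3 (0.29 log units; within the scatter) shows.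

Compound 4 `COc1ccc2c(=O)c(/C=C/C(=O)NCc3cccc(F)c3)coc2c1` has not yet been measured in this assay. It differs from compound 3 by 3-fluorobenzyl in place of 2-chlorophenyl on an amide-type nitrogen. Within the data shown here, only one measured step links two compounds directly, a 1.9-fold higher number from compound 2 to compound 3 (0.29 log units; within the scatter), for chloro in place of hydrogen on an aromatic carbon. That is a different change, and it stays small. Among the measured compounds shown here, no measured step makes the exchange at the amide-type nitrogen on the shared core. Compound 1, which gives 436000 nM, also has a benzyl group on an amide-type nitrogen, but its core differs from that of compound 4, so it offers only a loose guide. A step beyond the scatter is therefore not expected, only a slight lean towards that value. The expected change is a 1.7-fold lower number from compound 3 to compound 4 (0.23 log units; within the scatter). For compound 4 the estimated value is 600000 nM, with an expected range from 250000 nM to 1300000 nM.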

Compound 4, half-maximal cytotoxic concentration: 475000 nM
Compound 4: the middle estimate sits 1.3-fold (0.10 log units) above what was measured, within the range that was stated.
By their numbers in this assay, from the lowest: compounds 1, 4, 2 and 3 (each within the scatter of the next, the first and the last beyond it).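

The substituent on the amide-type nitrogen of the shared core now has a measured step in this assay: 3-fluorobenzyl in place of 2-chlorophenyl gives a 2.1-fold lower number from compound 3 to compound 4 (0.33 log units; beyond the scatter) and is modest in size. Set against the plain phenyl group, however, 3-fluorobenzyl gives a 1.1-fold lower number from compound 2 to compound 4 (0.04 log units; within the scatter) and cannot be separated from it. Read together, the two steps show that this position accepts a change from an aryl to a benzyl group with little movement in the number, and that the only separation seen at this nitrogen is the one measured against 2-chlorophenyl.

As far as these compounds go, what a plain benzyl group on the amide-type nitrogen of the shared core would give remains open, so the part played by the fluoro substituent in these steps cannot be told apart from that of the benzyl group itself. Also open, from the compounds shown here alone, is how a longer chain, or a group carrying an amine or a carboxylic acid, would read at this nitrogen in this assay and whether it would move the number further. No measurement at hand offers an explanation for these differences.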